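Swapping Chlorine for Fluorine on the Shared Core

The compounds below may be only part of what the source reports. "The series", "measured", "known", "first", "only" and "open" are said of these compounds alone.

Measured compounds:
compound 1 `CC1CCN(c2c(S(=O)(=O)c3ccc(C#N)cc3)cnc3cc(F)ccc23)CC1`: 83%
compound 2 `CC1CCN(c2c(S(=O)(=O)c3ccc(Cl)c(Cl)c3)cnc3cc(F)ccc23)CC1`: 94%
compound 3 `Cc1ccc(S(=O)(=O)c2cnc3cc(Cl)ccc3c2N2CCC(C)CC2)cc1F`: 85%

In an assay on isolated protein for displacement of a labelled ligand from metabotropic glutamate receptor 5 (Homo sapiens), with a stated time of 60 min, tested at 1 uM (on this read-out higher numbers stand for more inhibition at the one concentration tested (going by the name of the read-out) and lower numbers for less inhibition), compound 1 gives 83%, compound 2 gives 94% and compound 3 gives 85%. Compound 3 stands second of the three numbers, but its gap to compound 1 and its gap to compound 2 both lie within the usual scatter, so no order among the three can be claimed. For the measured compounds named here, the only measured step, a number 11 percentage points higher from compound 1 to compound 2 (beyond the scatter), changes the ring attached to the sulfonyl sulfur and leaves the shared core untouched.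

Compound 4 `Cc1ccc(S(=O)(=O)c2cnc3cc(F)ccc3c2N2CCC(C)CC2)cc1F` differs from compound 3 in one place: fluoro in place of chloro on an aromatic carbon. Going by the values given here, no measured pair makes this same exchange, so the one known step offers no direct guide; it shows only that a modest change elsewhere moved the number modestly. With nothing pointing in either direction, no step beyond the scatter is expected in this assay, and the estimated step of a number 1 percentage points lower from compound 3 to compound 4 (within the scatter) reflects that. Compound 4 is therefore expected to give 84%, with a likely range from 70% to 95%.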

Compound 4, a percentage reported as inhibition, at one concentration (the size of the read-out at that concentration, not a potency): 89%
Beside the measured number, compound 4's estimate is 5 percentage points below it; low and high end bracket the measured number.
By their numbers in this assay, from the lowest: compounds 1, 3, 4 and 2 (each within the scatter of the next, the first and the last beyond it).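

In this assay the exchange at this position gives a number 4 percentage points higher from compound 3 to compound 4 (within the scatter) and so, on this evidence, fluoro and chloro on this aromatic carbon cannot be told apart. On the sulfonyl sulfur, the comparison with 3-fluoro-4-methylphenyl gives a number 5 percentage points lower from compound 2 to compound 4 (within the scatter) and also a number 6 percentage points higher from compound 1 to compound 4 (within the scatter) and so this ring cannot be told apart from either of the other two, although a number 11 percentage points higher from compound 1 to compound 2 (beyond the scatter) separates those two from each other. There is no evidence on why the numbers fall as they do.

Going by these compounds, whether a methoxy group, an amine or a bare hydrogen on this aromatic carbon would keep the number in the same range stays open. So does whether fluoro and chloro would still look alike with 4-cyanophenyl or 3,4-dichlorophenyl on the sulfonyl sulfur.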